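The source may hold more compounds than are shown below. What is called first, only, known or untested is meant among the compounds shown, and "the series" means these compounds.

Measured so far:
- compound 1, `COC(=O)c1ccc(OC)c(S(=O)(=O)Nc2ccc3c(c2)cc(C)c(=O)n3C)c1`, gives 66% in a functional assay on HL-60 cells (Homo sapiens) for antiproliferative activity, tested at 100 uM; a lower number here means a weaker effect, a higher number a stronger effect of the compound at the concentration tested
- compound 2, `COc1cc(C(=O)NO)ccc1CS(=O)(=O)Nc1ccc2c(c1)cc(C)c(=O)n2C`, gives 0% in this assay

Compound 1 holds the higher of the two numbers; compound 2 sits far below it, beyond the scatter. The two structures differ in more than one place, so no single step can be read between them; the values only show that the whole series spans the full range from no effect to a clear effect.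

Compound 3, `COc1ccc(C(=O)NOCc2ccccc2)cc1S(=O)(=O)Nc1ccc2c(c1)cc(C)c(=O)n2C`, is not yet measured. It keeps the core of compound 1 and differs in one place: (benzyloxy)amino in place of methoxy on a carbonyl carbon. For the measured compounds named here, nothing in the measured pairs isolates this change, so no measured step guides it. The step of a number 21 percentage points lower from compound 1 to compound 3 (beyond the scatter) is expected to be a moderate loss, larger than the scatter, but with wide uncertainty. Compound 3 is estimated at 45%, with a range from 10% to 80%.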

Compound 3, a percentage reported as inhibition, at one concentration (the size of the read-out at that concentration, not a potency): 13%
For compound 3 the middle estimate is 32 percentage points above the measured one; the measured number falls inside the stated range.
By their numbers in this assay, from the lowest: compound 2; then compound 3; then compound 1.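

For the compounds shown here, replacing methoxy with (benzyloxy)amino on a carbonyl carbon gives the first single-place reading: in this assay, the change brings a number 53 percentage points lower from compound 1 to compound 3 (beyond the scatter). The shared core alone therefore does not preserve the read-out, and the group on this carbonyl carbon has a large bearing on it. No available measurement accounts for the loss.

The compounds shown do not separate the contribution of the added aromatic ring from that of the nitrogen-oxygen link in (benzyloxy)amino, so a plain benzylamino group or a benzyloxy ester would be informative at this place. As far as these compounds go, it also remains open whether a small change, such as ethoxy in place of methoxy, or a carboxylic acid on the same carbonyl carbon would retain the effect seen with compound 1.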